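Methoxy to phenoxy: working notes on compound 4

The source may hold more compounds than are shown below. What is called first, only, known or untested is meant among the compounds shown, and "the series" means these compounds.

In a functional assay on A549 cells (Homo sapiens) for inhibition, read by sulforhodamine B assay, with a stated time of 48 h, tested at 50 uM (on this read-out higher numbers stand for more inhibition of growth at the one concentration tested and lower numbers for less inhibition of growth), compound 1 (`COc1ccc([C@@H]2CC(=O)c3cc(CC=C(C)C)c(OC)cc3O2)cc1`) gives 45% and sits within the scatter of compound 3 (`COc1cc2c(cc1CC=C(C)C)[C@H](O)C[C@@H](c1ccc(O)cc1)O2`), which gives 48% in the same test. Compound 2 (`COc1ccc([C@@H]2C/C(=N/OCc3cn(-c4ccc(C(=O)c5ccccc5)cc4)nn3)c3cc(CC=C(C)C)c(OC)cc3O2)cc1`) gives 34% and lies beyond the scatter below compound 1.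

Compound 4 (`COc1cc2c(cc1CC=C(C)C)C(=O)C[C@@H](c1ccc(Oc3ccccc3)cc1)O2`) differs from compound 1 by phenyl in place of methyl on an oxygen on an aromatic ring, methoxy to phenoxy (phenyl in place of methyl on an oxygen on an aromatic ring). Going by the values given here, no measured pair isolates this change, so its direction remains open. With compound 2 at 34% despite a much larger addition to the core, a collapse of growth inhibition is not expected.

The expected step of a number 1 percentage points higher from compound 1 to compound 4 (within the scatter) stays within the scatter, with no firm direction in this assay for this change. Compound 4 is estimated at 46% within an expected range of 30% to 62% for repeated measurements.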

Compound 4, percent growth inhibition at one concentration: 46%
Estimate against measurement, compound 4: no gap at the digits printed; the range from low to high includes it.
By their numbers in this assay, from the lowest: compound 2; then compounds 1, 4 and 3 (each within the scatter of the next).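

The change from methoxy to phenoxy gives a number 1 percentage points higher from compound 1 to compound 4 (within the scatter) in this assay, the first step measured at this position. Phenyl in place of methyl on an oxygen on an aromatic ring is therefore accepted here without a firm shift in growth inhibition in either direction, even though the enlarged group brings an added six-membered aromatic ring. No measured property of either compound accounts for this result.

On these data alone, whether the same holds for other groups on that oxygen stays open: a butyl chain, or a chain ending in an amine or a carboxylic acid, has no reading in this set. The one concentration tested also leaves open whether compound 1 and compound 4 would separate at other concentrations.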